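Compound 4: a pentan-3-yl swap, expected flat

This account rests on a few compounds, and the source may have more. Where it says the series, first, only, none or still open, it means among the compounds named here.

Measured in a physicochemical assay for acid dissociation:
- compound 1 `COc1cccc(Oc2ccc3c(NCCCNCc4cccc(OC)c4O)ccnc3c2)c1`: 9.28
- compound 2 `COc1cccc(CNCCCNc2ccnc3cc(Cc4ccc(F)cc4)ccc23)c1O`: 9.47
- compound 3 `COc1cccc(CNCCCNc2ccnc3cc(Oc4cccc(N(C)C)c4)ccc23)c1O`: 9.28

Compound 3 sits level with compound 1 at the digits shown, and no measured number stands apart from it. The closest comparison gives no change at the digits printed from compound 1 to compound 3 (within the scatter), and the widest gives a number 0.19 log units lower from compound 2 to compound 3 (within the scatter).

The next structure is compound 4 `CCC(CC)c1ccc2c(NCCCNCc3cccc(OC)c3O)ccnc2c1`, with pentan-3-yl in place of 3-(dimethylamino)phenoxy on an aromatic carbon.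

Exchanges of a whole group on an aromatic carbon have been measured twice. Putting 4-fluorobenzyl in place of 3-methoxyphenoxy gave a number 0.19 log units higher from compound 1 to compound 2 (within the scatter), and putting 3-(dimethylamino)phenoxy in place of 4-fluorobenzyl gave a number 0.19 log units lower from compound 2 to compound 3 (within the scatter). The smaller exchange of dimethylamino in place of methoxy gave no change at the digits printed from compound 1 to compound 3 (within the scatter). All three steps stay within the scatter, so no step beyond the scatter is expected in this assay. The caution is that every measured compound carries a ring in this group, whereas pentan-3-yl has none, so the expectation reaches past the measured set.

The expected step is a number 0.07 log units higher from compound 3 to compound 4 (within the scatter). For compound 4 the estimated value is 9.35, with an expected range from 9.05 to 9.65.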

Compound 4, acid dissociation constant: 9.47
Compound 4: the middle estimate sits 0.12 log units below what was measured, within the range that was stated.
By their numbers in this assay, from the lowest: compounds 1, 3, 2 and 4 (each within the scatter of the next).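

In this assay the swap to pentan-3-yl reads as a number 0.19 log units higher from compound 3 to compound 4 (within the scatter) and as a number 0.19 log units higher from compound 1 to compound 4 (within the scatter) and, against the benzyl-linked group, as no change at the digits printed from compound 2 to compound 4 (within the scatter) in this series. Among the compounds shown here, this is the first group at this position without a ring, so the flat picture no longer depends on an aromatic ring in the group on this aromatic carbon, at least across compounds 1 to 4. The exchange also removes the 2 hydrogen-bond acceptors of 3-(dimethylamino)phenoxy and takes the group from 10 heavy atoms to 5, and the step still stays within the scatter; no measured reason for this flatness is available here.

Every group shown at this position is uncharged and carries carbon-rich bulk, so it remains open whether a primary amine or a carboxylic acid placed directly on this aromatic carbon would give a step beyond the scatter. Also open, on these data alone, is whether a change elsewhere, such as a longer chain between the two nitrogens of the linker, would move the number in a way that these substitutions at this position do not.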